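The source may report more compounds than this note shows. Statements on the series, on what has been measured and on what is new or still open speak of the compounds shown alone.

Measured in a functional assay on A549 cells (Homo sapiens) for antiproliferative activity, read by sulforhodamine B assay, with a stated time of 48 h; on this read-out higher numbers stand for weaker inhibition of growth and lower numbers for stronger inhibition of growth:
compound 1 `COc1ccc(Nc2nc(NCCCO)c3ccccc3n2)cc1`: 15200 nM
compound 2 `CNc1nc(Nc2ccc(OC)cc2)nc2ccccc12`: 16100 nM
compound 3 `COc1ccc(N(C)c2nc(NCCCO)c3ccccc3n2)cc1`: 13000 nM

The number for compound 1 lies within the scatter of both others. Compound 4 `Nc1ccc(Nc2nc(NCCCO)c3ccccc3n2)cc1` differs from it in one place, with amino in place of methoxy on an aromatic carbon, para to a large group (amino in place of methoxy on an aromatic carbon). The two measured steps (a 1.1-fold higher number from compound 1 to compound 2 (0.02 log units; within the scatter)) and (a 1.2-fold lower number from compound 1 to compound 3 (0.07 log units; within the scatter)) change other places and bear on this one only indirectly. Going by the values given here, both are small, and no measured compound shows what this exchange does. No step beyond the scatter is therefore expected (a 1.1-fold lower number from compound 1 to compound 4 (0.04 log units; within the scatter)). For compound 4 the estimated value is 14000 nM, with an expected range from 6000 nM to 30000 nM.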

Compound 4, concentration for 50% growth inhibition: 17100 nM
The estimate for compound 4 lay 1.2-fold (0.09 log units) below the measured number, and the stated range covers the measured number.
By their numbers in this assay, from the lowest: compounds 3, 1, 2 and 4 (each within the scatter of the next).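

In this assay, amino in place of methoxy on the aromatic carbon para to a large group gives a 1.1-fold higher number from compound 1 to compound 4 (0.05 log units; within the scatter). Going by these compounds alone, this is the first reading at this position, and the 4-aminophenyl compound shows that this exchange brings no step beyond the scatter. No measurement on hand accounts for this result.

The compounds shown leave open whether a carboxylic acid, a dimethylamino group or a longer chain on this aromatic carbon would shift the number beyond the scatter. They also leave open whether amino would act the same way on another carbon of this ring.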